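Bromo for methyl on a weak alpha-glucosidase inhibitor

This account rests on a few compounds, and the source may have more. Where it says the series, first, only, none or still open, it means among the compounds named here.

Measured compounds:
Compound 1 `CS/C(=C/C(=O)c1ccc(C)cc1)Nc1nc2ccccc2s1`, in an assay on isolated protein for inhibition of lysosomal alpha-glucosidase (Homo sapiens) (a higher number here means a weaker inhibitor, a lower number a stronger inhibitor), compound 1 gives 21100 nM.
Compound 2 `CCOc1ccc2nc(N/C(=C\C(=O)c3ccc(C)cc3)SC)sc2c1`, in this assay compound 2 gives "not active" (no number reported).

Compound 1 is a weak inhibitor on this scale. Compound 2 carries an ethoxy group on the shared core and is described only as inactive: no number was reported for compound 2 in this assay, so there is no fixed point from which a step could be counted. Compound 2 therefore stands at the bottom of what these two measurements show, below even the weak inhibition of compound 1.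

Compound 3 `CCOc1ccc2nc(N/C(=C\C(=O)c3ccc(Br)cc3)SC)sc2c1` keeps everything of compound 2 except one group on the aryl ketone: bromo in place of methyl on an aromatic carbon. Among the compounds with values here, with no pair of measured compounds spanning such a change, no size or direction for the step from compound 2 to compound 3 in this assay can be derived; the only guidance is that compound 2 is inactive and compound 1 is weak, so any effect is expected to be small and uncertain. On that basis compound 3 is expected to give about 35000 nM in this assay, with a likely range from 8000 nM to 150000 nM.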

Compound 3, half-maximal inhibitory concentration: "not active" (no number reported)
Compound 3 has no reported number here; the estimate stays without a comparison.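

Within the data shown here, compound 2 and compound 3 are both described only as not active in this assay, so no step from methyl to bromo can be read between them. No measured finding here offers an explanation for this result. The compounds shown leave open whether swapping 4-methylphenyl for 4-bromophenyl changes inhibition at all.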